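Triazole nitrogen substituent in the quinoline series

A few compounds are considered here, and "the series" means these few. Any claim that something is new, unique, unknown or untested is made for them only; others in the source may bear on it.

Compound 1 `CN(CCNCc1cn(-c2ccc(Br)cc2)nn1)CCNc1ccnc2cc(Cl)ccc12`: 11000 nM
Compound 2 `CN(CCNCc1cn(CCCO)nn1)CCNc1ccnc2cc(Cl)ccc12`: > 200000 nM

In a functional assay on HCC827 cells (Homo sapiens) for antiproliferative activity, read by sulforhodamine B assay, with a stated time of 72 h (a higher number here means a weaker inhibitor, a lower number a stronger inhibitor), compound 1 gives 11000 nM. Compound 2 gives only a limit, > 200000 nM. The step of an at least 18-fold higher number from compound 1 to compound 2 (1.25 log units; beyond the scatter) is therefore open-ended, because compound 2 sits at the limit of > 200000 nM in this assay, at which 1 of the 2 values shown sits. Compound 3 `CN(CCNCc1cn(-c2ccnc3cc(Cl)ccc23)nn1)CCNc1ccnc2cc(Cl)ccc12` reverses the direction of that step: 7-chloroquinolin-4-yl in place of 3-hydroxypropyl on an aromatic nitrogen, an aromatic group again taking the place the 4-bromophenyl held in compound 1. A step back of roughly the size of an at least 18-fold higher number from compound 1 to compound 2 (1.25 log units; beyond the scatter) is expected. Compound 3 is therefore estimated at 12000 nM (range 3000 nM to 60000 nM), an expected step of an at least 16-fold lower number from compound 2 to compound 3 (1.22 log units; beyond the scatter).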

Compound 3, half-maximal inhibitory concentration: 18000 nM
The estimate for compound 3 lay 1.5-fold (0.18 log units) below the measured number; the range from low to high includes it.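

Going by these compounds alone, at this aromatic nitrogen, 7-chloroquinolin-4-yl in place of 3-hydroxypropyl gives an at least 11-fold lower number from compound 2 to compound 3 (1.04 log units; beyond the scatter) in this assay, so 4-bromophenyl is not the only aromatic group that goes with a measurable value. The two aromatic groups are not told apart here: a 1.6-fold higher number from compound 1 to compound 3 (0.21 log units; within the scatter). Compound 2 gives only a limit of the assay, which leaves the size of the step from it open: the limit of > 200000 nM in this assay, at which 1 of the 3 values shown sits.

Going by these compounds, whether the gain depends on an aromatic ring as such, or on the size of the group, stays open. A benzyl group, or a longer chain ending in an amine, would help separate the two.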